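A few compounds are considered here, and "the series" means these few. Any claim that something is new, unique, unknown or untested is made for them only; others in the source may bear on it.

Compound 1 `CC(=O)Nc1nc(-c2cccc(NS(=O)(=O)c3ccc(C#CC4CCCCC4)cc3)c2)cs1`: 1.2%
Compound 2 `CC(=O)Nc1nc(-c2cccc(NS(=O)(=O)c3cccc(C#CCO)c3)c2)cs1`: 66.2%

Of the compounds shown here, two have been measured in a functional assay on A-375 cells (Homo sapiens) for antiproliferative activity, read by trypan blue exclusion, with a stated time of 48 h, tested at 5 uM; on this read-out lower numbers stand for a stronger effect and higher numbers for a weaker effect at the one concentration tested. Compound 1 gives 1.2%, the lowest of the two numbers, while compound 2 gives 66.2%, far higher and beyond the scatter. Compound 3 `CCCCCC/C=C\c1ccc(S(=O)(=O)Nc2cccc(-c3csc(NC(C)=O)n3)c2)cc1` is not yet measured. It differs from compound 1 by a group of 8 heavy atoms (8 carbon; no ring) in place of a group of 8 heavy atoms (8 carbon; one six-membered non-aromatic ring of carbon only), on an aromatic carbon. Since compound 1 already gives 1.2% and the new group keeps the count of 8 heavy atoms, the effect is expected to stay strong, with a step of a number 13.8 percentage points higher from compound 1 to compound 3 (beyond the scatter) expected, probably just beyond the scatter. Compound 3 is therefore estimated at 15%, within 2% to 45%.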

Compound 3, a percentage reported as activity, at one concentration (the size of the read-out at that concentration, not a potency): 2.3%
Estimate against measurement, compound 3: 12.7 percentage points above; the measured number falls inside the stated range.
By their numbers in this assay, from the lowest: compounds 1 and 3 (each within the scatter of the next); then compound 2.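

In this assay, putting an open chain with a double bond in place of 2-cyclohexylethynyl on this aromatic carbon gives a number 1.1 percentage points higher from compound 1 to compound 3 (within the scatter) and so shows that neither the six-membered ring nor the triple bond is needed here for the effect at the one concentration tested. No evidence bearing on this result is available. The compounds shown leave open whether an amine, a carboxylic acid or a short ethyl group in this place would keep the effect.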